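Mirror Image of a Weakly Cytotoxic Compound

The compounds below may be only part of what the source reports. "The series", "measured", "known", "first", "only" and "open" are said of these compounds alone.

In a functional assay on QGY cells (Homo sapiens) for cytotoxicity, read by MTT assay, with a stated time of 48 h (on this read-out higher numbers stand for weaker inhibition and lower numbers for stronger inhibition), compound 1 (`CCOC(=O)[C@@]1(C(=O)NCc2ccc(C)cc2)C[C@H]1c1cc(OC)c(OC)c(OC)c1`) gives 26400 nM and compound 2 (`CCOC(=O)[C@]1(C(=O)Nc2ccccc2Cl)C[C@@H]1c1cc(OC)c(OC)c(OC)c1`) gives 34700 nM with the two numbers lying within the usual scatter of each other. Compound 2 therefore stands level with compound 1. Compound 3 (`CCOC(=O)[C@@]1(C(=O)Nc2ccccc2Cl)C[C@H]1c1cc(OC)c(OC)c(OC)c1`) has the same atoms and bonds as compound 2 and differs only in configuration as drawn (the two compounds have the same atoms and bonds and differ only in configuration as drawn: 2 of 2 stereo elements differ (all stereocentres are inverted: mirror images); a stereocentre at a saturated ring carbon is drawn R in compound 2 and S in compound 3; a stereocentre at a saturated ring carbon is drawn R in compound 2 and S in compound 3) so the two are mirror images, like a left and a right hand. Mirror images may behave alike or differently, and no measured pair here shows which applies. Within the data shown here, the only direct anchor is compound 2 at 34700 nM so no clear direction is expected. The expected change is a 1.2-fold lower number from compound 2 to compound 3 (0.06 log units; within the scatter) and it is expected to stay within the scatter. For compound 3 the estimated value is 30000 nM with an expected range of 12000 nM to 70000 nM as the likely span.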

Compound 3, half-maximal inhibitory concentration: 34300 nM
Compound 3: middle estimate off by 1.1-fold (0.06 log units), on the low side; measured number inside the range.
By their numbers in this assay, from the lowest: compounds 1, 3 and 2 (each within the scatter of the next).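

In this assay, going to the mirror image gives a 1.0-fold lower number from compound 2 to compound 3 (0.01 log units; within the scatter), so inverting both stereocentres at the saturated ring carbons leaves the number within the scatter for this pair. This comparison tests handedness alone, because of one feature of the pair: the fact that compounds 2 and 3 differ only in the configuration as drawn. With the configuration as drawn now held the same, 2-chlorophenyl in place of 4-methylbenzyl on the amide-type nitrogen gives a 1.3-fold higher number from compound 1 to compound 3 (0.11 log units; within the scatter), so this swap of the amide group also stays within the scatter.

On these data alone, all three compounds carry the ethyl ester and the three methoxy groups, so it remains open whether a carboxylic acid in place of that ester, or an amine on the aromatic ring of the amide group, would shift the number. As far as these compounds go, it also remains open whether mirror images would still match with such a group in place.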